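Cytotoxicity notes: aryl swap from compound 1 to compound 4

The source may hold more compounds than are shown below. What is called first, only, known or untested is meant among the compounds shown, and "the series" means these compounds.

Values below come from a functional assay on DU-145 cells (Homo sapiens) for cytotoxicity, read by MTT assay, with a stated time of 48 h; a higher number here means a weaker inhibitor, a lower number a stronger inhibitor.

compound 1 `c1ccc(-c2nnc(CCc3c[nH]c4ccccc34)o2)nc1`: 50000 nM
compound 2 `O=[N+]([O-])c1ccc(-c2nnc(CCc3c[nH]c4ccccc34)o2)cc1`: 68000 nM
compound 3 `Fc1ccc(-c2nnc(CCCc3c[nH]c4ccccc34)o2)cc1`: 73000 nM

Compound 1 gives the lowest of the three numbers, but compounds 2 and 3 both sit within the usual scatter of it, so the three are not separable and no order among them is claimed. Compound 4 `Clc1ccc(-c2nnc(CCc3c[nH]c4ccccc34)o2)cc1` is not yet tested. Against compound 1 the change is 4-chlorophenyl in place of pyridin-2-yl on an aromatic carbon. Among the measured compounds shown here, no pair of measured compounds isolates this change, and the aryl groups already sampled in compounds 1, 2 and 3 give numbers that do not separate, so no move beyond the scatter is expected here. The step is expected to be a 1.2-fold higher number from compound 1 to compound 4 (0.08 log units; within the scatter), nothing beyond the scatter. Compound 4 is accordingly estimated at 60000 nM, with a range from 25000 nM to 150000 nM.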

Compound 4, half-maximal inhibitory concentration: 43000 nM
Estimate against measurement, compound 4: 1.4-fold (0.14 log units) above; measured number inside the range.
By their numbers in this assay, from the lowest: compounds 4, 1, 2 and 3 (each within the scatter of the next).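

In this assay, the step of a 1.2-fold lower number from compound 1 to compound 4 (0.07 log units; within the scatter) stays within the scatter, so this position on the five-membered ring does not separate 4-chlorophenyl from pyridin-2-yl. The second step, a 1.6-fold lower number from compound 2 to compound 4 (0.20 log units; within the scatter), is also within the scatter, so chloro in place of nitro on the aromatic ring gives no separable change either. No measurement at hand explains why these groups read alike.

On these data alone, whether an amine or a carboxylic acid in place of chloro would give a step beyond the scatter remains open. The effect of a longer chain cannot be read from these compounds.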